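The source may report more compounds than this note shows. Statements on the series, on what has been measured and on what is new or still open speak of the compounds shown alone.

Measured so far:
compound 1 `CCCCCCCCCCCCCCN1C[C@H](CO)NC(=O)[C@@H]1C(C)C` — 2700 nM
compound 2 `CCCCCCCCCCCCCCN1C[C@@H](CO)NC(=O)[C@@H]1C(C)C` — 290 nM

In an assay on isolated protein for displacement of a labelled ligand from protein kinase C delta type (Homo sapiens) (a lower number here means a stronger inhibitor, a higher number a weaker inhibitor), compound 2 gives 290 nM, the lowest of the two numbers recorded, while compound 1 gives 2700 nM. The only step measured, a 9.3-fold lower number from compound 1 to compound 2 (0.97 log units; beyond the scatter), rests on the fact that the two compounds share every atom and bond and differ in configuration at a single saturated ring carbon; that much is shown by the fact that compounds 1 and 2 differ only in the configuration as drawn.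

Compound 3 `CCCCCCCCCCCCCCN1C[C@H](CO)NC(=O)[C@H]1C(C)C` is the next step. It is the mirror image of compound 2: the two compounds have the same atoms and bonds and differ only in configuration as drawn: 2 of 2 stereo elements differ (all stereocentres are inverted: mirror images); a stereocentre at a saturated ring carbon is drawn S in compound 2 and R in compound 3; a stereocentre at a saturated ring carbon is drawn S in compound 2 and R in compound 3. For the measured compounds named here, the one measured step bears on it only indirectly, since it concerns a single centre, whereas here both are inverted. Still, it shows that configuration alone moved the number substantially between compound 1 and compound 2, so a change of similar or larger size in this assay, toward a higher number, is expected for compound 3, as a 10-fold higher number from compound 2 to compound 3 (1.01 log units; beyond the scatter). Compound 3 is therefore estimated at 3000 nM, within a range from 700 nM to 15000 nM.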

Compound 3, inhibition constant: 12000 nM
The estimate for compound 3 lay 4.0-fold (0.60 log units) below the measured number; low and high end bracket the measured number.
By their numbers in this assay, from the lowest: compound 2; then compound 1; then compound 3.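

In this assay, the ring stereocentre left untouched by the earlier pair also matters, since inverting that one carbon gives a 4.4-fold higher number from compound 1 to compound 3 (0.65 log units; beyond the scatter), and only the configuration changes: the fact that compounds 1 and 3 differ only in the configuration as drawn Each of the two ring stereocentres has thus now been seen to move the number on its own, and the drawing with S at both centres, compound 2, gives the lowest number of the three, with its steps to the other two compounds beyond the scatter. Inverting both centres at once gives a 41-fold higher number from compound 2 to compound 3 (1.62 log units; beyond the scatter), the largest step yet seen here, so the two mirror images are clearly told apart in this assay, again with no change other than configuration: the fact that compounds 2 and 3 differ only in the configuration as drawn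

The compounds shown leave open where the fourth combination of the two centres would fall, and so whether the effect of inverting one centre holds when the other is inverted too. They also leave open how far this preference for compound 2 would carry over to analogues with a shorter chain, or with an amine or a carboxylic acid on the ring.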